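The compounds below may be only part of what the source reports. "The series", "measured", "known", "first", "only" and "open" are said of these compounds alone.

Three compounds have been measured so far in an assay on HEK293 cells for agonist activity at transient receptor potential cation channel subfamily M member 8 (Homo sapiens), read by fluorescence and calcium flux, with a stated time of 15 min; on this read-out lower numbers stand for an effect already at smaller amounts and higher numbers for an effect only at larger amounts of compound:

Compound 1 `CCN(Cc1cccs1)C(=O)COc1ccc(C(F)(F)F)cc1`: 236 nM
Compound 2 `CCN(Cc1cccs1)C(=O)COc1ccccc1`: 1400 nM
Compound 3 `COc1ccc(OCC(=O)N(Cc2cccs2)c2ccn[nH]2)cc1`: 3.7 nM

Compound 3 holds the lowest number of the three. Compound 1 stands nearest to it, yet compound 1 still gives 236 nM, and compound 2 stands furthest away with 1400 nM; both gaps are well beyond the scatter. The only step measured between two of these compounds is a 5.9-fold higher number from compound 1 to compound 2 (0.77 log units; beyond the scatter), a change on the aromatic ring that carries the ether oxygen, not on the amide nitrogen.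

Compound 4 `CCN(Cc1cccs1)C(=O)COc1ccc(OC)cc1` has not yet been measured. It differs from compound 3 in one place: ethyl in place of 1H-pyrazol-5-yl on an amide-type nitrogen. Among the compounds with values here, no measured step covers this exchange, so its size cannot be read from the data directly. What the data do show is that compounds 1 and 2, which carry the same ethyl on the amide nitrogen as compound 4, both sit far above compound 3 in this assay. On that basis a large step upward is expected, a 140-fold higher number from compound 3 to compound 4 (2.13 log units; beyond the scatter). For compound 4 the estimated value in this assay is 500 nM, with a range from 100 nM to 3000 nM.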

Compound 4, half-maximal effective concentration: 120 nM
Compound 4: middle estimate off by 4.2-fold (0.62 log units), on the high side, within the range that was stated.
By their numbers in this assay, from the lowest: compound 3; then compounds 4 and 1 (each within the scatter of the next); then compound 2.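

In this assay, within the data shown here, the exchange on the amide-type nitrogen now has a measured size of its own: with the rest of the structure unchanged, ethyl in place of 1H-pyrazol-5-yl gives a 32-fold higher number from compound 3 to compound 4 (1.51 log units; beyond the scatter), a large step that the earlier compounds could not isolate, as they differed from compound 3 in two places. On the aromatic carbon, methoxy in place of hydrogen gives a 12-fold lower number from compound 2 to compound 4 (1.07 log units; beyond the scatter), whereas a 2.0-fold lower number from compound 1 to compound 4 (0.29 log units; within the scatter) stays within the scatter, so methoxy and trifluoromethyl cannot be told apart at this place, and the change at the amide-type nitrogen remains the larger one for compound 4. No independent measurement is available to explain the size of either change.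

The compounds shown leave open whether 1H-pyrazol-5-yl on the amide-type nitrogen brings a step of similar size when trifluoromethyl or hydrogen replaces the methoxy group. They also leave open what a propyl chain, a phenyl ring or a chain ending in an amine would give on that nitrogen, and so whether the ring itself matters there.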